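Lengthening the Linker in Three Close Relatives

The source may hold more compounds than are shown below. What is called first, only, known or untested is meant among the compounds shown, and "the series" means these compounds.

Of the compounds shown here, three built on one shared core have been tested in a functional assay on HCT-116 cells (Homo sapiens) for antiproliferative activity, read by CCK-8 assay, with a stated time of 72 h, tested at 2 uM; a lower number here means a weaker effect, a higher number a stronger effect of the compound at the concentration tested. Compound 1 `CCCCn1cnc2c(Nc3cccc(Cl)c3)nc(NCOCc3ccc(/C=C/C(=O)Nc4ccccc4N)cc3)nc21` gives 4.76% in this assay. Among the measured compounds shown here, compound 2 `Nc1ccccc1NC(=O)/C=C/c1ccc(COCNc2nc(Nc3cccc(Cl)c3)c3ncn(C4CCCC4)c3n2)cc1` gives 9.04%, and the only change between them, cyclopentyl in place of butyl on an aromatic nitrogen, brought a number 4.3 percentage points higher from compound 1 to compound 2 (within the scatter). Compound 3 `CC(C)n1cnc2c(Nc3cccc(Cl)c3)nc(NCOCc3ccc(C(=O)Nc4ccccc4N)cc3)nc21` gives 7.12%, which stands second highest of the three numbers, yet both of its neighbours lie within the scatter of it, so the three are not told apart.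

Compound 4 `CC(C)n1cnc2c(Nc3cccc(Cl)c3)nc(NCOCc3ccc(/C=C/C(=O)Nc4ccccc4N)cc3)nc21` has not yet been measured. It differs from compound 3 in one place: 2-((2-aminophenyl)carbamoyl)ethenyl in place of (2-aminophenyl)carbamoyl on an aromatic carbon. For the measured compounds named here, no measured pair shows exactly this change, so its effect has to be judged from the whole set. Compounds 1 and 2 already carry the longer group and sit within the scatter of compound 3. For compound 4 the expected step is therefore a number 0.1 percentage points lower from compound 3 to compound 4 (within the scatter), no change beyond the scatter. The estimated value of compound 4 is 7%, likely between 0% and 17%.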

Compound 4, a percentage reported as inhibition, at one concentration (the size of the read-out at that concentration, not a potency): 18.5%
For compound 4 the middle estimate is 11.5 percentage points below the measured one; measured number above the stated range.
By their numbers in this assay, from the lowest: compounds 1, 3, 2 and 4 (each within the scatter of the next, the first and the last beyond it).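

In this assay, 2-((2-aminophenyl)carbamoyl)ethenyl in place of (2-aminophenyl)carbamoyl, para to a large group, brings a number 11.4 percentage points higher from compound 3 to compound 4 (beyond the scatter) and so shows that this change can move the read-out, which compounds 1, 2 and 3 alone could not show. With the ethenyl group held fixed, the group on the aromatic nitrogen also counts in one case: isopropyl in place of butyl brings a number 13.7 percentage points higher from compound 1 to compound 4 (beyond the scatter) while isopropyl in place of cyclopentyl brings a number 9.5 percentage points higher from compound 2 to compound 4 (within the scatter) and so does not separate those two groups. No measurement on these compounds offers a reason for these steps.

Going by these compounds, the shorter (2-aminophenyl)carbamoyl group appears only with isopropyl, so whether the gain holds with butyl or cyclopentyl on the aromatic nitrogen stays open. Also open, on these data alone, is how a saturated ethyl linker in place of the ethenyl would compare.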